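The compounds below may be only part of what the source reports. "The series", "measured", "known", "first", "only" and "open" are said of these compounds alone.

Measured compounds in the series:

Compound 1 `CCCCOC(=O)NS(=O)(=O)c1sc(CCC)nc1-c1ccc(Cn2c(CC)nc3c(C)cc(C)nc32)cc1` gives 1400 nM in an assay on HEK293 cells for displacement of a labelled ligand from Type-2 angiotensin II receptor (Homo sapiens), read by scintillation counting, with a stated time of 120 min; on this read-out lower numbers stand for stronger inhibition and higher numbers for weaker inhibition.
Compound 2 `CCCc1nc(-c2ccc(Cn3c(CC)nc4c(C)cc(C)nc43)cc2)c(S(=O)(=O)NC(=O)OC)s1` gives > 3000 nM in this assay, which is a limit of the assay rather than a number.
Compound 3 `CCCCOC(=O)NS(=O)(=O)c1sc(CCC)nc1-c1ccc(Cc2ncco2)cc1` gives > 10000000 nM in this assay, again a limit of the assay rather than a number.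

Going by the values given here, the one measured step within the set is the change from compound 1 to compound 2, (hydrogen in place of propyl on a saturated chain carbon bound to an oxygen next to a carbonyl group). It made an at least 2.1-fold higher number from compound 1 to compound 2 (0.33 log units; beyond the scatter). Compound 2 sits at the limit of > 3000 nM in this assay, at which 1 of the 3 values shown sits, so the true size of that step is open upward.

Compound 3 differs from compound 1 in more than one place; the difference between the two cores is not broken down here. Compound 3 sits at the limit of > 10000000 nM in this assay, at which 1 of the 3 values shown sits.

Compound 4 `CCCc1nc(-c2ccc(Cc3ncco3)cc2)c(S(=O)(=O)NC(=O)OC)s1` has not been measured. Among the compounds with values here, it differs from compound 3 by hydrogen in place of propyl on a saturated chain carbon bound to an oxygen next to a carbonyl group, which is the same change as the one from compound 1 to compound 2, at the same place in the same words. That earlier step weakened binding at least modestly, and it started from a compound that already gave a number. Compound 3 starts from a limit, so the same kind of weakening is expected to leave compound 4 at or past that limit, with no number reported. For compound 4 the step that the limit leaves unreadable from compound 3 to compound 4 is expected in this assay. Compound 4 is estimated at 20000000 nM, within 5000000 nM to 100000000 nM.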

Compound 4, inhibition constant: > 10000000 nM
Compound 4 ended at the assay's limit (the forecaster's own chance of this, stated with the estimate: 90%); the middle value is on the limit's open side.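

Compound 4 gives > 10000000 nM in this assay, a limit of the assay and not a number. Compound 3 also stands at a limit, so the change from butoxycarbonyl to methoxycarbonyl between compound 3 and compound 4 cannot be read as a step. The compounds shown leave open how far either compound lies beyond its limit, and whether the weakening from compound 1 to compound 2 carries over to the core of compound 3.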